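Chloro to Methylsulfanyl: Estimating a Single Substituent Swap

This account rests on a few compounds, and the source may have more. Where it says the series, first, only, none or still open, it means among the compounds named here.

Of the compounds shown here, three with a shared core have been tested in a functional assay on aorta with Alpha-1D adrenergic receptor (Rattus norvegicus) as the target; a higher number here means that more compound is needed for the effect, a lower number that less compound is needed. Compound 1, `CSc1ccc(Cc2nn(C(C)(C)C)c(=O)c3ccccc23)cc1`, gives only a limit in this assay, > 100000 nM. Compound 2, `CCn1nc(Cc2ccc(SC)cc2)c2ccccc2c1=O`, likewise gives only a limit, > 100000 nM. The step from compound 1 to compound 2, a step that the two limits leave unreadable from compound 1 to compound 2, therefore cannot be sized, and the limit of > 100000 nM in this assay, at which 2 of the 3 values shown sit, marks where these two values sit. Going by the values given here, compound 3, `O=c1c2ccccc2c(Cc2ccc(Cl)cc2)nn1-c1ccc([N+](=O)[O-])cc1`, is the only one with an actual number: in this assay compound 3 gives 29000 nM.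

Compound 4, `CSc1ccc(Cc2nn(-c3ccc([N+](=O)[O-])cc3)c(=O)c3ccccc23)cc1`, differs from compound 3 in one place: methylsulfanyl in place of chloro on an aromatic carbon. Among the compounds with values here, no measured step touches this position. Compound 1 and compound 2 carry the same methylsulfanyl group, but they differ from compound 4 elsewhere as well, so their values give no readable step for this change. The expectation for compound 4 is therefore loose: it is expected to be somewhat weaker than compound 3, a step of a 1.7-fold higher number from compound 3 to compound 4 (0.24 log units; within the scatter), with a real chance that only a limit is reported. The estimate for compound 4 is 50000 nM, within 15000 nM to 150000 nM.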

Compound 4, half-maximal effective concentration: > 100000 nM
Compound 4: only a limit was reported; the forecaster's own chance of this, stated with the estimate: 40%; middle value at least 2.0-fold (0.30 log units) from the limit.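

Going by these compounds alone, with the 4-nitrophenyl group unchanged, methylsulfanyl in place of chloro on the aromatic carbon gives an at least 3.4-fold higher number from compound 3 to compound 4 (0.53 log units; beyond the scatter) in this assay, the first readable evidence that this position responds to the change and that more compound is needed with methylsulfanyl. Compound 4 gives only a limit, which makes this step a minimum rather than an exact size, and the steps from compound 1 and from compound 2 to compound 4 cannot be read. The comparison rests on a single actual number, with the other compounds all sitting at the same limit: the limit of > 100000 nM in this assay, at which 3 of the 4 values shown sit.

From the compounds shown here alone, how far compound 4 lies beyond its limit remains open. Also open, going by these compounds, is whether a methoxy group or an amine at this position would stay closer to compound 3 or whether a chloro group would give a measurable number with ethyl or tert-butyl on the aromatic nitrogen.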